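Amide-nitrogen substituents across compounds 1 to 4

A few compounds are considered here, and "the series" means these few. Any claim that something is new, unique, unknown or untested is made for them only; others in the source may bear on it.

Compound 3 `CCC[C@H](NC(=O)[C@@H]1C[C@@H]2CN1C(=O)[C@H](C(C)(C)C)NC(=O)OCCCCCCc1cccc3c1CN(C3)C(=O)O2)C(=O)C(=O)NC(C)c1ccccc1` is the reference point. In an ADME assay on Huh-7 cells (Homo sapiens) for cytotoxicity (on this read-out lower numbers stand for higher toxicity in this test and higher numbers for lower toxicity in this test), compound 3 gives > 50000 nM, which is a limit of the assay rather than a number. Compound 1 `CCC[C@H](NC(=O)[C@@H]1C[C@@H]2CN1C(=O)[C@H](C(C)(C)C)NC(=O)OCCCCCCc1cccc3c1CN(C3)C(=O)O2)C(=O)C(=O)NC1CCCC1` gives > 50000 nM in this assay, also a limit. Compound 2 `C=CCNC(=O)C(=O)[C@H](CCC)NC(=O)[C@@H]1C[C@@H]2CN1C(=O)[C@H](C(C)(C)C)NC(=O)OCCCCCCc1cccc3c1CN(C3)C(=O)O2` gives > 50000 nM in this assay, again a limit. All three values sit at the limit of > 50000 nM in this assay, at which 3 of the 3 values shown sit, so the steps a step that the two limits leave unreadable from compound 1 to compound 2, a step that the two limits leave unreadable from compound 1 to compound 3 and a step that the two limits leave unreadable from compound 2 to compound 3 carry no readable size or direction.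

Compound 4 `CCC[C@H](NC(=O)[C@@H]1C[C@@H]2CN1C(=O)[C@H](C(C)(C)C)NC(=O)OCCCCCCc1cccc3c1CN(C3)C(=O)O2)C(=O)C(=O)NCc1ccccn1` differs from compound 3 by (pyridin-2-yl)methyl in place of 1-phenylethyl on an amide-type nitrogen. Going by the values given here, no measured step bears on this change with a readable size; the earlier substituent swaps on the same nitrogen left every value at the limit. Compound 4 is therefore expected to stay at that limit as well, with an estimated 60000 nM (range 30000 nM to 200000 nM). The expected step is a step that the limit leaves unreadable from compound 3 to compound 4, nothing beyond the scatter.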

Compound 4, half-maximal cytotoxic concentration: > 50000 nM
Compound 4 ended at the assay's limit (the forecaster's own chance of this, stated with the estimate: 85%); the middle value does not contradict the limit.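

In this assay, the steps among compound 1, compound 2, compound 3 and compound 4 cannot be read, and each value is a limit of the assay: the limit of > 50000 nM in this assay, at which 4 of the 4 values shown sit.

The compounds shown leave open whether any substituent on this amide-type nitrogen changes the read-out, and in which direction.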